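A few compounds are considered here, and "the series" means these few. Any claim that something is new, unique, unknown or untested is made for them only; others in the source may bear on it.

In a functional assay on Ehrlich cells (Mus musculus) for cytotoxicity, read by LDH release, with a stated time of 48 h (a higher number here means a weaker inhibitor, a lower number a stronger inhibitor), compound 1 (`Cc1cc(C(=O)c2ccccc2)ccc1OCC(=O)Nc1nc(-c2ccccc2)cs1`) gives 24500 nM as its half-maximal inhibitory concentration. Its relative compound 2 (`Cc1cc(C(=O)c2ccccc2)cc(C)c1OCC(=O)Nc1nc(-c2ccccc2)cs1`) gives 23400 nM in the same test. These two values lie within the scatter of each other, so neither can be ranked above the other. Compound 3 (`Cc1cc(C(=O)c2ccccc2F)ccc1OCC(=O)Nc1nc(-c2ccccc2)cs1`) has not yet been measured. It differs from compound 1 by one change: fluoro in place of hydrogen on an aromatic carbon. In words, this is fluoro in place of hydrogen on an aromatic carbon, turning phenyl into 2-fluorophenyl. Within the data shown here, only one measured step offers any guide, a 1.0-fold lower number from compound 1 to compound 2 (0.02 log units; within the scatter), and it places methyl rather than fluoro on an aromatic carbon, so it bears on this change only loosely. It gives no sign of a large effect from so small an addition. The expected result in this assay is a 1.1-fold lower number from compound 1 to compound 3 (0.03 log units; within the scatter), with no change beyond the scatter and no favoured direction. For compound 3 the estimated value is 23000 nM, within an expected range of 10000 nM to 48000 nM.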

Compound 3, half-maximal inhibitory concentration: 16900 nM
The estimate for compound 3 lay 1.4-fold (0.13 log units) above the measured number, and the stated range covers the measured number.
By their numbers in this assay, from the lowest: compounds 3, 2 and 1 (each within the scatter of the next).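

Fluoro in place of hydrogen, turning phenyl into 2-fluorophenyl, gives a 1.4-fold lower number from compound 1 to compound 3 (0.16 log units; within the scatter) in this assay. Among these compounds, the earlier step placed methyl on the other aromatic ring, so this is the first reading from the phenyl of the benzoyl group, and it shows that a single fluoro there does not move the number beyond the usual scatter of repeated measurements. Nothing shown here offers an explanation for this small step, and a step inside the scatter cannot show a real effect in either direction.

From the compounds shown here alone, it remains open whether a larger group on this same ring, such as trifluoromethyl, methoxy or an amine, would shift the number beyond the scatter. Going by these compounds, it is also open whether fluoro elsewhere on this ring would behave as it does here.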